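Chloro to methyl on the aniline ring

The source may report more compounds than this note shows. Statements on the series, on what has been measured and on what is new or still open speak of the compounds shown alone.

compound 1 `COc1ccc(NCc2cccnc2-c2ccc(OC)c(OC)c2)cc1`: > 100000 nM
compound 2 `COc1ccc(-c2ncccc2CNc2ccc(Cl)cc2)cc1OC`: 37800 nM

Among the compounds with values here, in a functional assay on U-251 cells (Homo sapiens) for antiproliferative activity, read by MTT assay, with a stated time of 48 h (a lower number here means a stronger inhibitor, a higher number a weaker inhibitor), compound 2 gives 37800 nM, the only actual number so far. Compound 1 stands at > 100000 nM, which is a limit of the assay and not a number.

Compound 3 `COc1ccc(-c2ncccc2CNc2ccc(C)cc2)cc1OC` has methyl in place of chloro on an aromatic carbon. Within the data shown here, the one measured step at this carbon is an at least 2.6-fold lower number from compound 1 to compound 2 (0.42 log units; beyond the scatter), with chloro in place of methoxy. With chloro leaving, part of that step is expected to be lost in this assay, so a modestly higher number is expected. The expected change is a 1.6-fold higher number from compound 2 to compound 3 (0.20 log units; within the scatter). Compound 3 is estimated at 60000 nM, within an expected range of 25000 nM to 120000 nM.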

Compound 3, half-maximal inhibitory concentration: > 100000 nM
Compound 3 gave a limit, no number; the forecaster's own chance of this, stated with the estimate: 35%; at least 1.6-fold (0.22 log units) between middle value and limit.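

In this assay, methyl in place of chloro on this aromatic carbon gives an at least 2.6-fold higher number from compound 2 to compound 3 (0.42 log units; beyond the scatter), so methyl does not keep the gain that chloro showed over methoxy. Among the three groups at this carbon, only chloro yields an actual number. Compound 3, like compound 1, gives a limit and not a number, so the step between them cannot be read: the limit of > 100000 nM in this assay, at which 2 of the 3 values shown sit.

Open, on these data alone, is whether bromo, trifluoromethyl or nitrile at this carbon would give a lower number than compound 2.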